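Swapping a chlorobenzyl for isobutyl on the sulfonamide nitrogen

A few compounds are considered here, and "the series" means these few. Any claim that something is new, unique, unknown or untested is made for them only; others in the source may bear on it.

Compound 1 `Cc1ccc(CN2c3ccccc3C(=O)N(Cc3ccccc3)S2(=O)=O)cc1` gives 63000 nM in a functional assay on MRC5 cells (Homo sapiens); a higher number here means that more compound is tolerated, a lower number that less compound is tolerated.
Compound 2 `O=C1c2ccccc2N(Cc2cccc(Cl)c2)S(=O)(=O)N1Cc1ccccc1` gives 60000 nM in this assay.

Compound 2 stands lowest of the two numbers in this assay, with compound 1 nearest; the step of a 1.1-fold lower number from compound 1 to compound 2 (0.02 log units; within the scatter) shows the two are not separated. Compound 3 `CC(C)CN1c2ccccc2C(=O)N(Cc2ccccc2)S1(=O)=O` differs from compound 2 by isopropyl in place of 3-chlorophenyl on a saturated chain carbon bound to a sulfonamide nitrogen in a ring. Within the data shown here, the only measured step, from compound 1 to compound 2, exchanged one aromatic group for another at the same place and moved nothing beyond the scatter; no step with a group that lacks a ring is known. Compound 3 is therefore expected to stay close, the step of a 1.2-fold higher number from compound 2 to compound 3 (0.07 log units; within the scatter) lying within or near the scatter. Compound 3 is estimated at 70000 nM, between 30000 nM and 150000 nM.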

Compound 3, half-maximal cytotoxic concentration: 72000 nM
Compound 3: the middle estimate sits 1.0-fold (0.01 log units) below what was measured; the measured number falls inside the stated range.
By their numbers in this assay, from the lowest: compounds 2, 1 and 3 (each within the scatter of the next).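

Where compounds 1 and 2 carry an aromatic ring at this place, compound 3 carries none, and in this assay the numbers still stay within the scatter. Isopropyl in place of 3-chlorophenyl gives a 1.2-fold higher number from compound 2 to compound 3 (0.08 log units; within the scatter) and isopropyl in place of 4-methylphenyl gives a 1.1-fold higher number from compound 1 to compound 3 (0.06 log units; within the scatter) at the same place. Across these three compounds, then, the number does not depend on a ring at this place, and nothing at hand offers an explanation. As far as these compounds go, it remains open whether an amine or a carboxylic acid on this saturated chain carbon would move the number beyond the scatter.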